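The source may report more compounds than this note shows. Statements on the series, on what has been measured and on what is new or still open speak of the compounds shown alone.

Measured so far:
compound 1 `COc1cc(N2C(N)=C(C#N)C(c3ccc(OC)c4ccccc34)C3=C2CC(C)(C)CC3=O)cc(OC)c1OC` gives 30% in a functional assay on Ehrlich cells (Mus musculus) for cytotoxicity, tested at 25 ug/mL; on this read-out higher numbers stand for a stronger effect at the one concentration tested and lower numbers for a weaker effect;
compound 2 `COc1cc(N2C(N)=C(C#N)C(c3ccc([N+](=O)[O-])cc3)C3=C2CC(C)(C)CC3=O)cc(OC)c1OC` gives 50%;
compound 3 `COc1cc(N2C(N)=C(C#N)C(c3cccs3)C3=C2CC(C)(C)CC3=O)cc(OC)c1OC` gives 10%.

On these numbers compound 3 stands lowest of the three, below both others beyond the scatter. Compound 4 `COc1cc(N2C(N)=C(C#N)C(c3ccccc3Cl)C3=C2CC(C)(C)CC3=O)cc(OC)c1OC` differs from compound 3 in one place: 2-chlorophenyl in place of thiophen-2-yl on a saturated ring carbon. Within the data shown here, two measured steps bear on this change, both ending at the thiophen-2-yl compound: a number 20 percentage points lower from compound 1 to compound 3 (beyond the scatter) and a number 40 percentage points lower from compound 2 to compound 3 (beyond the scatter). Each time thiophen-2-yl replaced another aromatic group, the reading fell. Going the other way, a rise beyond the scatter is therefore expected for compound 4, of modest size; 2-chlorophenyl is neither of the two aromatic groups already seen, so the expectation is kept cautious. The expected step is a number 25 percentage points higher from compound 3 to compound 4 (beyond the scatter). Compound 4 is estimated at 35%, in the range 15% to 55%.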

Compound 4, a percentage reported as activity, at one concentration (the size of the read-out at that concentration, not a potency): 15%
Beside the measured number, compound 4's estimate is 20 percentage points above it, within the range that was stated.
By their numbers in this assay, from the lowest: compounds 3 and 4 (each within the scatter of the next); then compound 1; then compound 2.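

In this assay, 2-chlorophenyl in place of thiophen-2-yl on this saturated ring carbon gives a number 5 percentage points higher from compound 3 to compound 4 (within the scatter), so a six-membered aromatic ring of carbon only does not by itself separate the two. The same group in place of the other aromatic groups gives a number 35 percentage points lower from compound 2 to compound 4 (beyond the scatter) and a number 15 percentage points lower from compound 1 to compound 4 (beyond the scatter), which shows that 4-nitrophenyl and 4-methoxynaphthalen-1-yl each stand apart from 2-chlorophenyl here. Nothing available explains these differences. On these data alone, it stays open how a phenyl ring carrying an amine or a carboxylic acid would read at this carbon, and whether plain phenyl would read with compound 4 or apart from it.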